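Xanthine series: bromomethyl to imide chain, compound 3 to 4

The source may hold more compounds than are shown below. What is called first, only, known or untested is meant among the compounds shown, and "the series" means these compounds.

Measured so far, in an assay for binding affinity to adenosine receptor A1 (Rattus norvegicus), tested at 50 nM; a lower number here means less inhibition, a higher number more inhibition at the concentration tested (going by the name of the read-out):
compound 1 `CCCn1c(=O)c2nc(-c3ccc(OCC(=O)NCCN=C(S)Nc4ccc(N=C=S)cc4)cc3)[nH]c2n(CCC)c1=O` gives 29%
compound 2 `CCCn1c(=O)c2nc(-c3ccc(OCC(=O)NCCNC(=O)CBr)cc3)[nH]c2n(CCC)c1=O` gives 16%
compound 3 `CCCn1c(=O)c2nc(-c3ccc(OCC(=O)NCCNC(=O)c4ccc(CBr)cc4)cc3)[nH]c2n(CCC)c1=O` gives 15%

Compound 3 holds the lowest number of the three in this assay. Its nearest neighbour is compound 2, and the step of a number 1 percentage points lower from compound 2 to compound 3 (within the scatter) lies within the scatter, so the two cannot be ordered against each other. Compound 1 sits farther off, beyond the scatter, with a higher number than compound 3.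

The next compound, compound 4 `CCCn1c(=O)c2nc(-c3ccc(OCC(=O)NCCNC(=O)CCCN4C(=O)C=CC4=O)cc3)[nH]c2n(CCC)c1=O`, differs from compound 3 in one place: a group of 10 heavy atoms (7 carbon, 1 nitrogen, 2 oxygen; one five-membered non-aromatic ring with 1 hetero atom) in place of a group of 8 heavy atoms (7 carbon, 1 bromine; one six-membered aromatic ring of carbon only), on a carbonyl carbon. Among the compounds with values here, of the measured steps only the one from compound 2 to compound 3 touches the same position, the carbonyl carbon next to the amide-type nitrogen, and that step, a number 1 percentage points lower from compound 2 to compound 3 (within the scatter), stayed within the scatter. Swapping the 4-(bromomethyl)phenyl for the five-membered non-aromatic ring carried on a chain is a larger change than the earlier one, but nothing measured speaks for a shift in either direction. The step of a number 2 percentage points higher from compound 3 to compound 4 (within the scatter) is therefore expected to stay within the scatter. For compound 4 the expected value in this assay is 17%, with a range from 5% to 30%.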

Compound 4, a percentage reported as inhibition, at one concentration (the size of the read-out at that concentration, not a potency): 15%
The estimate for compound 4 lay 2 percentage points above the measured number, within the range that was stated.
By their numbers in this assay, from the lowest: compounds 3, 4 and 2 (each within the scatter of the next); then compound 1.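

Working notes on the position. In this assay, the carbonyl carbon whose other neighbour is the amide-type nitrogen now carries a group with a five-membered non-aromatic ring with 1 hetero atom and 2 hydrogen-bond acceptors, in place of 4-(bromomethyl)phenyl with its six-membered aromatic ring and 0 hydrogen-bond acceptors, and the result is no change at the digits printed from compound 3 to compound 4 (within the scatter). Set against the smaller bromine-bearing end, the exchange gives a number 1 percentage points lower from compound 2 to compound 4 (within the scatter), so three quite different ends on this chain, in compound 2, compound 3 and compound 4, cannot be told apart in this assay at the one concentration tested, and neither the aromatic ring, nor the bromine, nor the added hydrogen-bond acceptors separate them here. Nothing available on these compounds accounts for this lack of separation.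

Still open, on these data alone, is whether a terminal amine or a carboxylic acid in this place, or a longer chain ahead of the five-membered ring, would leave the number in the same region. As far as these compounds go, a read-out at one concentration also gives no potency, so any difference among compound 2, compound 3 and compound 4 that a full concentration series might show remains unknown.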